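Swapping the aminophenyl ketone of compound 1 for difluorophenyl

The source may report more compounds than this note shows. Statements on the series, on what has been measured and on what is new or still open speak of the compounds shown alone.

Measured compounds:
compound 1 `COc1cc(-c2cc(/C=C/C(=O)c3ccc(N)cc3)[nH]n2)cc(OC)c1OC`: -38%
compound 2 `COc1ccc(-c2cc(/C=C/C(=O)c3ccc(N)cc3)[nH]n2)cc1OC`: -19%

In a functional assay on HT-29 cells (Homo sapiens) for cytotoxicity, read by sulforhodamine B assay, with a stated time of 48 h, tested at 10 uM (a lower number here means a stronger effect, a higher number a weaker effect of the compound at the concentration tested), compound 1 gives -38%, the lowest of the two numbers; compound 2 gives -19%. Among the measured compounds shown here, the single measured step, a number 19 percentage points higher from compound 1 to compound 2 (beyond the scatter), concerns the ring carrying the methoxy groups and not the carbonyl side. Compound 3 `COc1cc(-c2cc(/C=C/C(=O)c3ccc(F)c(F)c3)[nH]n2)cc(OC)c1OC` differs from compound 1 exactly there: 3,4-difluorophenyl in place of 4-aminophenyl on a carbonyl carbon. For the measured compounds named here, no measured step bears on this exchange, so no direction beyond the scatter can be foreseen. Compound 3 is therefore expected to give about -25%, within -60% to 10%. The step expected for compound 3 is a number 13 percentage points higher from compound 1 to compound 3 (beyond the scatter), set wide for lack of precedent.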

Compound 3, a percentage reported as activity, at one concentration (the size of the read-out at that concentration, not a potency): -24%
Beside the measured number, compound 3's estimate is 1 percentage points below it, within the range that was stated.
By their numbers in this assay, from the lowest: compound 1; then compounds 3 and 2 (each within the scatter of the next).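

In this assay, among the compounds shown here, the exchange of 4-aminophenyl for 3,4-difluorophenyl on a carbonyl carbon gives a number 14 percentage points higher from compound 1 to compound 3 (beyond the scatter), the first measured step on this side of the molecule. The read-out thus responds to this position, yet compound 3 still gives -24% without the hydrogen-bond donor of the group that leaves. No measured evidence accounts for this step. The compounds shown leave open how a single fluorine, a hydroxyl group or a dimethylamino group on that phenyl would read. They also leave open whether 3,4-difluorophenyl would give a similar step with another substitution pattern of methoxy groups.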